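A few compounds are considered here, and "the series" means these few. Any claim that something is new, unique, unknown or untested is made for them only; others in the source may bear on it.

Measured compounds:
compound 1 `Cc1ccc(N2CCN(S(=O)(=O)c3ccc4c(c3)CC(=O)N4)CC2)cc1` gives "not active" (no number reported) in an assay on isolated protein for inhibition of lysosomal alpha-glucosidase (Homo sapiens), read by fluorescence, with stated times of 5 min and 45 min; a higher number here means a weaker inhibitor, a lower number a stronger inhibitor;
compound 2 `N#Cc1ccc(N2CCN(S(=O)(=O)c3ccc4c(c3)CC(=O)N4)CC2)cc1` gives 2910 nM in this assay;
compound 3 `O=C1Cc2cc(S(=O)(=O)N3CCN(c4ccc([N+](=O)[O-])cc4)CC3)ccc2N1` gives 3660 nM in this assay.

Compound 1 thus stands apart: it has no single number, only a report of no activity, while compounds 2 and 3 both gave numbers. Among the measured compounds shown here, the one counted step, a 1.3-fold higher number from compound 2 to compound 3 (0.10 log units; within the scatter), is within the scatter and concerns a different group, so it does not bear directly on the change now considered. Compound 4 `O=C1Cc2cc(S(=O)(=O)N3CCN(c4ccc(C(F)(F)F)cc4)CC3)ccc2N1` differs from compound 1 by trifluoromethyl in place of methyl on an aromatic carbon. For the measured compounds named here, no measured step tells how large an effect that change has in this assay, so the expectation for compound 4 rests only on compounds 2 and 3 carrying a number and compound 1 carrying none. Compound 4 is estimated at 6000 nM, between 1500 nM and 30000 nM.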

Compound 4, half-maximal inhibitory concentration: "not active" (no number reported)
Nothing numeric was reported for compound 4, and the estimate cannot be compared.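

Compound 1 and compound 4 were both reported as not active, without a number, so no step can be read between them. No further data bear on this result. The compounds shown leave open how trifluoromethyl and methyl compare at this place.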